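A few compounds are considered here, and "the series" means these few. Any claim that something is new, unique, unknown or untested is made for them only; others in the source may bear on it.

Compound 1, `CC/N=C(\S)CCn1nc(-c2ccccc2)ccc1=O`, gives 50.3% in a functional assay on the whole organism (stomach) for inhibition, with Rattus norvegicus as the target, at a dose of 100 mg/kg by the intraduodenal route; a higher number here means more inhibition at the dose given (going by the name of the read-out), a lower number less inhibition.
Compound 2, `N=C(S)CCCCCCn1nc(-c2ccccc2)ccc1=O`, gives 33.9% in this assay.
Compound 3, `Cc1ccc(=O)n(CCCCC(=N)S)n1`, gives 29.5% in this assay.

Compound 3 gives the lowest of the three numbers, but its gap to compound 2 lies within the usual scatter, so the two cannot be told apart; only compound 1 stands clearly higher than compound 3.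

Compound 4, `N=C(S)CCCCn1nc(-c2ccccc2)ccc1=O`, differs from compound 3 in one place: phenyl in place of methyl on an aromatic carbon. Within the data shown here, the only step between measured compounds, a number 16.4 percentage points lower from compound 1 to compound 2 (beyond the scatter), changes the chain that carries the thioamide group, not the substituent on the core, so it does not bear directly on this change. Compounds 1 and 2 both carry the phenyl group and both give higher numbers than compound 3, but they also differ from compound 3 in the chain, so the phenyl group alone cannot be credited. A modest rise in this assay is therefore expected, about a number 8.5 percentage points higher from compound 3 to compound 4 (within the scatter), with wide uncertainty. Compound 4 is estimated to give 38%, within a range from 22% to 55%.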

Compound 4, a percentage reported as inhibition, in the whole organism at one dose (the size of the read-out at that dose, not a potency): 33.8%
The estimate for compound 4 lay 4.2 percentage points above the measured number; the measured number falls inside the stated range.
By their numbers in this assay, from the lowest: compounds 3, 4 and 2 (each within the scatter of the next); then compound 1.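

In this assay the swap of phenyl for methyl on the aromatic carbon gives a number 4.3 percentage points higher from compound 3 to compound 4 (within the scatter) and so does not tell the two compounds apart at this dose. Among the compounds that carry phenyl, a change in the chain gives a number 0.1 percentage points lower from compound 2 to compound 4 (within the scatter) but also a number 16.5 percentage points lower from compound 1 to compound 4 (beyond the scatter) and so the clear gap here lies in the chain that carries the thioamide group, not in the swap on the core. No measurement at hand explains these numbers.

Going by these compounds, whether phenyl and methyl would also stay within the scatter of each other on the chain of compound 1 remains open. So does the outcome for other groups on this aromatic carbon, such as an amine or a carboxylic acid, and the read-out at one dose gives no potency for any of these compounds.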